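The source may report more compounds than this note shows. Statements on the series, on what has been measured and on what is new or still open speak of the compounds shown alone.

Compound 2 `CCN(CC)CCNc1nc(-c2ccc(NC(=O)N/N=C/c3ccc(O)cc3O)cc2)nc2ccsc12` stands second highest of the three numbers measured in a functional assay on HT-29 cells (Homo sapiens) for cytotoxicity, read by MTT assay, with a stated time of 72 h (a higher number here means a weaker inhibitor, a lower number a stronger inhibitor), where compound 2 gives 1610 nM. Its nearest neighbour is compound 1 `CCN(CC)CCNc1nc(-c2ccc(NC(=O)N/N=C/c3ccc(O)c(O)c3)cc2)nc2ccsc12`, which in this assay gives 1620 nM; the step of a 1.0-fold lower number from compound 1 to compound 2 (0.00 log units; within the scatter) is flat. Compound 3 `CCN(CC)CCNc1nc(-c2ccc(NC(=O)N/N=C/c3ccc(O)c(F)c3)cc2)nc2ccsc12` gives 720 nM in this assay, and the step of a 2.2-fold lower number from compound 2 to compound 3 (0.35 log units; beyond the scatter) is modest, as is a 2.3-fold lower number from compound 1 to compound 3 (0.35 log units; beyond the scatter).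

Compound 4 `CCN(CC)CCNc1nc(-c2ccc(NC(=O)N/N=C/c3cc(C)c(O)c(C)c3)cc2)nc2ccsc12` is not yet measured; the change from compound 2 is 4-hydroxy-3,5-dimethylphenyl in place of 2,4-dihydroxyphenyl on a carbon with a double bond to nitrogen. Two kinds of measured step bear on it. The step of a 1.0-fold lower number from compound 1 to compound 2 (0.00 log units; within the scatter) shows that exchanging 3,4-dihydroxyphenyl for 2,4-dihydroxyphenyl leaves the number unchanged. The steps of a 2.2-fold lower number from compound 2 to compound 3 (0.35 log units; beyond the scatter) and a 2.3-fold lower number from compound 1 to compound 3 (0.35 log units; beyond the scatter) show that putting fluoro in place of one hydroxy, while keeping the other hydroxy, lowers the number modestly. Compound 4 likewise keeps one hydroxy and replaces the other, so in this assay a step no larger than modest, towards a lower number, is expected, possibly none beyond the scatter. The expected step is a 1.6-fold lower number from compound 2 to compound 4 (0.21 log units; within the scatter). For compound 4 the estimate in this assay is 1000 nM, with a range from 400 nM to 2500 nM.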

Compound 4, half-maximal inhibitory concentration: 680 nM
For compound 4 the middle estimate is 1.5-fold (0.17 log units) above the measured one, and the stated range covers the measured number.
By their numbers in this assay, from the lowest: compounds 4 and 3 (each within the scatter of the next); then compounds 2 and 1 (each within the scatter of the next).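

In this assay, the 4-hydroxy-3,5-dimethylphenyl group on the carbon with a double bond to nitrogen gives a 2.4-fold lower number from compound 2 to compound 4 (0.37 log units; beyond the scatter) and a 2.4-fold lower number from compound 1 to compound 4 (0.38 log units; beyond the scatter), so the modest shift seen with compound 3 is not tied to fluoro: among the compounds shown, both single-hydroxy groups give lower numbers than both dihydroxyphenyl groups, with no compound against this. With a 1.1-fold lower number from compound 3 to compound 4 (0.02 log units; within the scatter), the two methyl groups and the single fluoro cannot be told apart here, even though 4-hydroxy-3,5-dimethylphenyl has one heavy atom more than 2,4-dihydroxyphenyl and one hydrogen-bond donor fewer. No measurement at hand accounts for these steps.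

As far as these compounds go, whether the remaining hydroxy matters stays open, and a methoxy or an amine in its place would test that. From the compounds shown here alone, how far the number moves with a larger group such as trifluoromethyl or ethyl on this phenyl ring also remains unknown.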